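Removing a methyl from the methoxy group on the shared core

The compounds below may be only part of what the source reports. "The series", "measured", "known", "first", "only" and "open" are said of these compounds alone.

Measured compounds:
compound 1 `COc1cc(-c2nn(-c3cccc(NC(=O)c4ccc(Cl)c(C(F)(F)F)c4)c3)cc2-c2ccncc2)ccc1Cl`: 8040 nM
compound 2 `COc1cc(-c2nn(-c3cccc(NC(=O)Nc4ccc(Cl)c(C(F)(F)F)c4)c3)cc2-c2ccncc2)ccc1Cl`: 1290 nM
compound 3 `COc1cc(-c2nn(-c3cccc(NC(=O)c4ccccc4)c3)cc2-c2ccncc2)ccc1Cl`: 1170 nM

In a functional assay on OVCAR-4 cells (Homo sapiens) for inhibition, read by sulforhodamine B assay, with a stated time of 48 h (on this read-out higher numbers stand for weaker inhibition of growth and lower numbers for stronger inhibition of growth), compound 1 gives 8040 nM, compound 2 gives 1290 nM and compound 3 gives 1170 nM. Compound 2 sits second highest of the three, with a 1.1-fold lower number from compound 2 to compound 3 (0.04 log units; within the scatter) keeping it within the scatter of compound 3, while a 6.2-fold lower number from compound 1 to compound 2 (0.79 log units; beyond the scatter) sets it well apart from compound 1.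

Compound 4 `O=C(Nc1cccc(-n2cc(-c3ccncc3)c(-c3ccc(Cl)c(O)c3)n2)c1)Nc1ccc(Cl)c(C(F)(F)F)c1` differs from compound 2 in one place: hydrogen in place of methyl on an oxygen on an aromatic ring

Among the compounds with values here, none of the measured steps touches this position. The steps of a 6.2-fold lower number from compound 1 to compound 2 (0.79 log units; beyond the scatter) and a 6.9-fold lower number from compound 1 to compound 3 (0.84 log units; beyond the scatter) concern the group on the carbonyl carbon, which is the same in compound 2 and compound 4, so they give no guide to the size or direction of this change. With nothing to go on, the expected step of a 1.2-fold higher number from compound 2 to compound 4 (0.07 log units; within the scatter) is none beyond the scatter. Compound 4 is therefore estimated at 1500 nM, with a range from 450 nM to 5000 nM.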

Compound 4, concentration for 50% growth inhibition: 1200 nM
Compound 4: middle estimate off by 1.3-fold (0.10 log units), on the high side; measured number inside the range.
By their numbers in this assay, from the lowest: compounds 3, 4 and 2 (each within the scatter of the next); then compound 1.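

The swap from methoxy to hydroxy is the first change shown at this position, and it comes to a 1.1-fold lower number from compound 2 to compound 4 (0.03 log units; within the scatter) in this assay. The read-out therefore does not separate the two compounds. With the (4-chloro-3-(trifluoromethyl)phenyl)amino group on the carbonyl carbon, the methyl on this oxygen can give way to hydrogen with no measurable cost to growth inhibition, and no supporting measurement offers a reason for this result.

Hydroxy appears here only in compound 4, so it remains open whether the same swap would be as quiet with the groups on the carbonyl carbon of compound 1 or compound 3. Also open, on these data alone, is how a longer chain on this oxygen, such as ethoxy, or an amine in place of the hydroxy would behave.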